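From Methyl to Azidomethyl: What to Expect for Compound 4

The source may report more compounds than this note shows. Statements on the series, on what has been measured and on what is new or still open speak of the compounds shown alone.

Compound 2 `C[C@H]1OC(CO)C(O)C(O)C1O` was tested in an assay on isolated protein (Oryctolagus cuniculus) for binding affinity to glycogen phosphorylase, brain form (Homo sapiens) (on this read-out lower numbers stand for stronger inhibition and higher numbers for weaker inhibition), and gives 53100000 nM. Among the measured compounds shown here, this is the highest of the three numbers measured so far, although its distance to compound 1 `NC[C@H]1OC(CO)C(O)C(O)C1O`, which gives 34500000 nM, lies within the usual scatter; compound 3 `NCC[C@@H]1OC(CO)C(O)C(O)C1O` gives 4500000 nM. Compound 4 `[N-]=[N+]=NC[C@H]1OC(CO)C(O)C(O)C1O` differs from compound 2 by azido in place of hydrogen on a saturated chain carbon bound to a saturated ring carbon. For the measured compounds named here, the only measured step that touches the same place is a 1.5-fold higher number from compound 1 to compound 2 (0.19 log units; within the scatter), where taking an amino group off that carbon barely moved the number. Adding an azido group there is therefore expected to shift the number only slightly, if at all beyond the scatter. Compound 4 is expected to give 35000000 nM, between 9000000 nM and 110000000 nM, meaning a step of a 1.5-fold lower number from compound 2 to compound 4 (0.18 log units; within the scatter).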

Compound 4, inhibition constant: 22400000 nM
Beside the measured number, compound 4's estimate is 1.6-fold (0.19 log units) above it, within the range that was stated.
By their numbers in this assay, from the lowest: compound 3; then compounds 4, 1 and 2 (each within the scatter of the next, the first and the last beyond it).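

In this assay, this carbon now shows a step beyond the scatter: azido in place of hydrogen gives a 2.4-fold lower number from compound 2 to compound 4 (0.37 log units; beyond the scatter) and is modest in size, while the exchange of amino and hydrogen stayed within the scatter. Azido in place of amino gives a 1.5-fold lower number from compound 1 to compound 4 (0.19 log units; within the scatter) and so does not separate these two groups here. No measurement at hand offers a reason for the step. As far as these compounds go, whether a carboxylic acid on this carbon would move the number further stays open, as does whether azido in place of amino in compound 3 would give a similar step.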